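The source may hold more compounds than are shown below. What is called first, only, known or untested is meant among the compounds shown, and "the series" means these compounds.

Measured in a functional assay on A549 cells (Homo sapiens) for cytotoxicity, read by MTT assay; on this read-out lower numbers stand for stronger inhibition and higher numbers for weaker inhibition:
- Compound 1 `O=c1oc2ccccc2c(O)c1-c1cc(-c2ccc(F)cc2)nc(O)n1`: 2390 nM
- Compound 2 `COc1cccc(C2CC(c3c(O)c4ccccc4oc3=O)=NN2)c1`: 5910 nM
- Compound 3 `O=c1oc2ccccc2c(O)c1C1=NNC(c2ccc(F)cc2)C1`: 1050 nM

Of the three, compound 3 gives the lowest number in this assay. Compound 4 `O=c1oc2ccccc2c(O)c1C1=NNC(c2c(F)cccc2Cl)C1` carries 2-chloro-6-fluorophenyl in place of 4-fluorophenyl on a saturated ring carbon. Among the measured compounds shown here, only one measured step bears on this place, a 5.6-fold lower number from compound 2 to compound 3 (0.75 log units; beyond the scatter), and it shows that changing the aryl group there can move the number modestly. For the measured compounds named here, it says nothing about this particular substitution pattern, so a small upward drift is expected, no larger than that step, and the direction is uncertain. The expected change is a 1.3-fold higher number from compound 3 to compound 4 (0.12 log units; within the scatter). Compound 4 is estimated at 1400 nM, with an expected range from 450 nM to 4200 nM.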

Compound 4, half-maximal inhibitory concentration: 23500 nM
For compound 4 the middle estimate is 17-fold (1.22 log units) below the measured one; the measured number lies above the stated range.
By their numbers in this assay, from the lowest: compound 3; then compound 1; then compound 2; then compound 4.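

The aryl group on this saturated ring carbon can move the number much further than the earlier step showed: in this assay, 2-chloro-6-fluorophenyl in place of 4-fluorophenyl gives a 22-fold higher number from compound 3 to compound 4 (1.35 log units; beyond the scatter). The new group also falls behind 3-methoxyphenyl, with a 4.0-fold higher number from compound 2 to compound 4 (0.60 log units; beyond the scatter), so the change does more than reverse the earlier gain. No measurement at hand bears on why the number rises. As far as these compounds go, it remains open how an unsubstituted phenyl or a cyclohexyl group would read at this carbon, and whether the chlorine alone accounts for the step.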